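The compounds below may be only part of what the source reports. "The series", "measured", "known", "first", "only" and "open" are said of these compounds alone.

Values in a functional assay on V79 cells (Cricetulus griseus) for cytotoxicity, read by colony formation; on this read-out lower numbers stand for stronger inhibition and higher numbers for weaker inhibition:
- compound 1 `COc1c(N2CCCC2)c(F)cc2c(=O)c(C(=O)O)cn(C3CC3)c12`: 150 ug/mL
- compound 2 `CCNCC1CCN(c2c(F)cc3c(=O)c(C(=O)O)cn(C4CC4)c3c2OC)C1`: 22 ug/mL; 22 ug/mL (2 entries)
- compound 3 `CC1(CN)CCN(c2c(F)cc3c(=O)c(C(=O)O)cn(C4CC4)c3c2Cl)C1`: 8 ug/mL

Compound 3, at 8 ug/mL, holds the lowest number of the three, and compound 1 lies above it by more than the scatter. Compound 4 `COc1c(N2CCC(C)(CN)C2)c(F)cc2c(=O)c(C(=O)O)cn(C3CC3)c12` keeps the 3-(aminomethyl)-3-methylpyrrolidin-1-yl group of compound 3 and differs from it as follows: methoxy in place of chloro on an aromatic carbon. This places methoxy in place of chloro on an aromatic carbon. For the measured compounds named here, no measured pair isolates this change, so any expectation rests on indirect evidence. Compound 2 carries methoxy but has a different side chain, and it gives 22 ug/mL; 22 ug/mL (2 entries). Compound 1 also carries methoxy and gives 150 ug/mL. On that basis, a modest rise in this assay is expected, toward weaker inhibition, and it may not clear the scatter by much. The estimated change is a 2.5-fold higher number from compound 3 to compound 4 (0.40 log units; beyond the scatter). For compound 4 the expected value is 20 ug/mL, with an estimated range of 8 ug/mL to 60 ug/mL.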

Compound 4, half-maximal inhibitory concentration: 38 ug/mL
Estimate against measurement, compound 4: 1.9-fold (0.28 log units) below; measured number inside the range.
By their numbers in this assay, from the lowest: compound 3; then compound 4; then compound 1.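

In this assay, methoxy in place of chloro on an aromatic carbon, with the 3-(aminomethyl)-3-methylpyrrolidin-1-yl group held constant, gives a 4.8-fold higher number from compound 3 to compound 4 (0.68 log units; beyond the scatter) and so provides the only direct reading of this change among these compounds. With methoxy kept, 3-(aminomethyl)-3-methylpyrrolidin-1-yl in place of pyrrolidin-1-yl gives a 3.9-fold lower number from compound 1 to compound 4 (0.60 log units; beyond the scatter) in this assay, so each of the two places moves the number by a step beyond the scatter. No measurement at hand accounts for either step.

The compounds shown leave open how ethoxy, bromo or a plain hydrogen on this aromatic carbon would compare with chloro and methoxy. Also open, going by these compounds, is whether the step from chloro to methoxy keeps its size with another side chain, such as a piperazine.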